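The source may hold more compounds than are shown below. What is called first, only, known or untested is meant among the compounds shown, and "the series" means these compounds.

Three compounds have values so far in a functional assay on SW620/5-FU cells (Homo sapiens) for cytotoxicity, read by MTT assay, with a stated time of 48 h, in the presence of a further agent that is not named here; a lower number here means that less compound is needed, a higher number that more compound is needed for the effect

Compound 1 `COc1cc(NC(=O)NNc2cc(-c3ccccc3)c3cnn(C)c3n2)cc(Cl)n1` gives 28700 nM
Compound 2 `COc1ccc(-c2cc(NNC(=O)Nc3cc(Cl)nc(OC(C)C)c3)nc3c2cnn3C)cc1` gives 47100 nM
Compound 3 `CCN(CC)c1cc(NC(=O)NNc2cc(-c3ccc(F)cc3)c3cnn(C)c3n2)cc(Cl)n1` gives 37000 nM

These three values lie close together, and both compound 1 and compound 2 fall within the scatter of compound 3, so compound 3 cannot be separated from either of them on these numbers.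

Compound 4 `COc1cc(NC(=O)NNc2cc(-c3ccc(F)cc3)c3cnn(C)c3n2)cc(Cl)n1` has not yet been measured. It follows from compound 3 by one change, methoxy in place of diethylamino on an aromatic carbon and the rest of the structure stays the same.

Going by the values given here, no two measured compounds differ in only one place, so no direct step is available as a guide. Compound 1 already carries methoxy and gives 28700 nM in this assay while compound 3 gives 37000 nM and on that basis no step beyond the scatter is expected, in either direction. The estimated step is a 1.2-fold lower number from compound 3 to compound 4 (0.08 log units; within the scatter) and it is expected to stay small. For compound 4 the expected value is 31000 nM with an estimated range from 15000 nM to 62000 nM in this assay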

Compound 4, half-maximal effective concentration: 24100 nM
Compound 4: middle estimate off by 1.3-fold (0.11 log units), on the high side; the measured number falls inside the stated range.
By their numbers in this assay, from the lowest: compounds 4, 1, 3 and 2 (each within the scatter of the next).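

In this assay, going by these compounds alone, the position next to the ring nitrogen can now be read directly for the first time: methoxy in place of diethylamino gives a 1.5-fold lower number from compound 3 to compound 4 (0.19 log units; within the scatter) and stays within the scatter. Replacing a group of five heavy atoms with one of two therefore leaves no change that can be told apart at this position in this assay. With methoxy held in place, fluoro in place of hydrogen on an aromatic carbon gives a 1.2-fold lower number from compound 1 to compound 4 (0.08 log units; within the scatter) and also stays within the scatter. Nothing available explains why either step is this small. On these data alone, it remains open whether a primary amine, a carboxylic acid or a longer alkoxy chain at this position would give a step beyond the scatter. As far as these compounds go, it also remains open whether any change here would matter on a compound with a much lower number.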